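The source may hold more compounds than are shown below. What is called first, only, known or untested is meant among the compounds shown, and "the series" means these compounds.

Of the compounds shown here, three sharing one core have been measured in a functional assay for inhibition of sodium/hydrogen exchanger (Oryctolagus cuniculus); a lower number here means a stronger inhibitor, a higher number a weaker inhibitor. Compound 1 `Cc1cc(Br)c(S(C)(=O)=O)cc1C(=O)N=C(N)N` carries a bromo group on an aromatic carbon, and in this assay compound 1 gives 12 nM. Compound 2 `Cc1cc(C2CCC2)c(S(C)(=O)=O)cc1C(=O)N=C(N)N` carries a cyclobutyl group in that place; in this assay compound 2 gives 8.2 nM, and the step of a 1.5-fold lower number from compound 1 to compound 2 (0.17 log units; within the scatter) stays within the scatter. Compound 3 `Cc1cc(-c2cc(Cl)cc(Cl)c2)c(S(C)(=O)=O)cc1C(=O)N=C(N)N` carries a 3,5-dichlorophenyl group there, and in this assay compound 3 gives 130 nM, the highest of the three numbers, since the steps of an 11-fold higher number from compound 1 to compound 3 (1.03 log units; beyond the scatter) and a 16-fold higher number from compound 2 to compound 3 (1.20 log units; beyond the scatter) are both large and beyond the scatter. Compound 4 `Cc1cc(Sc2ccccc2)c(S(C)(=O)=O)cc1C(=O)N=C(N)N` has not yet been measured. It differs from compound 3 in one place: phenylsulfanyl in place of 3,5-dichlorophenyl on an aromatic carbon. The two large steps leading to compound 3 both bring in a six-membered carbon ring, and compound 4 keeps such a ring, now joined through a sulfur, so a number closer to compound 3 than to compound 1 or compound 2 seems likely, perhaps somewhat lower. For compound 4 the estimated value in this assay is 70 nM, with a range from 20 nM to 250 nM. This estimate means an expected step of a 1.9-fold lower number from compound 3 to compound 4 (0.27 log units; within the scatter).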

Compound 4, half-maximal inhibitory concentration: 14 nM
Estimate against measurement, compound 4: 5.0-fold (0.70 log units) above; the whole stated range lies above it.
By their numbers in this assay, from the lowest: compounds 2, 1 and 4 (each within the scatter of the next); then compound 3.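

Carrying a six-membered aromatic ring of carbon only at this position does not by itself give a weaker inhibitor: phenylsulfanyl keeps such a ring, yet in this assay the change gives a 9.3-fold lower number from compound 3 to compound 4 (0.97 log units; beyond the scatter). Phenylsulfanyl also reads level with cyclobutyl and bromo, at a 1.7-fold higher number from compound 2 to compound 4 (0.23 log units; within the scatter) and a 1.2-fold higher number from compound 1 to compound 4 (0.07 log units; within the scatter), so this position tolerates all three alike, and 3,5-dichlorophenyl is the one group that goes against this. Nothing available here explains the difference between these two groups.

This change removes two chlorine atoms and brings in a sulfur link at once, so a plain phenyl joined directly, or a 3,5-dichlorophenylsulfanyl group, would be needed to tell these two parts apart. Also open, on these data alone, is how an amine or a carboxylic acid at this position would read in this assay.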